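From 2,2-difluoroethoxy to cyclopropylmethoxy in compound 1

This account rests on a few compounds, and the source may have more. Where it says the series, first, only, none or still open, it means among the compounds named here.

Compound 1 (`O=C(O)Cn1nc(Cc2nc3cc(Cl)c(OCC(F)F)cc3[nH]2)c2ccccc2c1=O`): 33 L/kg
Compound 2 (`C[C@H](C(=O)O)n1nc(Cn2cc3cc(OCC4CC4)c(Cl)cc3n2)c2ccccc2c1=O`): 168 L/kg
Compound 3 (`C[C@H](C(=O)O)c1nn(Cc2cn3cc(OCC4CC4)c(Cl)cc3n2)c2ccccc2c1=O`): 17 L/kg

In an ADME assay on the whole organism (Mus musculus, strain CD1) for pharmacokinetics, read by LC-MS, with a stated time of 24 h, at a dose of 1 mg/kg by the intravenous route (on this read-out lower numbers stand for narrower distribution and higher numbers for wider distribution into tissues), compound 1 gives 33 L/kg and stands within the scatter of compound 3. It lies beyond the scatter of compound 2 on the lower side, and that is its widest gap among the three.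

Compound 4 (`O=C(O)Cn1nc(Cc2nc3cc(Cl)c(OCC4CC4)cc3[nH]2)c2ccccc2c1=O`) keeps the core of compound 1 but carries cyclopropyl in place of difluoromethyl on a saturated chain carbon bound to an oxygen on an aromatic ring. Among the measured compounds shown here, no measured pair differs in one place only, so this assay gives no direct size for this change. Compound 2 at 168 L/kg and compound 3 at 17 L/kg both carry cyclopropylmethoxy, but they differ elsewhere and their values lie far apart, so they fix no direction. The expected result is a 1.2-fold higher number from compound 1 to compound 4 (0.08 log units; within the scatter) with no step beyond the scatter. Compound 4 is expected at 40 L/kg with an estimated range from 15 L/kg to 110 L/kg in this assay for now.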

Compound 4, volume of distribution at steady state: 83 L/kg
For compound 4 the middle estimate is 2.1-fold (0.32 log units) below the measured one; the range from low to high includes it.
By their numbers in this assay, from the lowest: compounds 3 and 1 (each within the scatter of the next); then compound 4; then compound 2.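

In this assay, among the compounds shown here, putting cyclopropyl in place of difluoromethyl on a saturated chain carbon bound to an oxygen on an aromatic ring gives a 2.5-fold higher number from compound 1 to compound 4 (0.40 log units; beyond the scatter), the first direct reading of this change on the core of compound 1. It shows that this position is not silent on this read-out: the two groups have the same count of heavy atoms, yet the step is modest and still lies beyond the scatter. Nothing measured here bears on what lies behind the step.

This single step leaves open whether the change would run the same way on a different core, since no matched pair on another core is shown. Also open, on these data alone, is how a trifluoromethyl group or a longer chain would read in the same place.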